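Compound 4: an aryl group replaces the amino end

The source may hold more compounds than are shown below. What is called first, only, known or untested is meant among the compounds shown, and "the series" means these compounds.

compound 1 `COc1cc(NC(C)CCCNC(=O)NN)c2ncccc2c1` gives 16000 nM
compound 2 `COc1cc(NC(C)CCCNC(=O)NNC(=O)N(C)C(c2ccccc2)c2ccccc2)c2ncccc2c1` gives 5000 nM
compound 3 `O=C1NCCN1C(c1ccccc1)(c1ccccc1)c1ccccc1` gives 63000 nM

All three values come from a functional assay on MCF7 cells (Homo sapiens) for inhibition, read by MTT assay, with a stated time of 4 days (on this read-out lower numbers stand for stronger inhibition and higher numbers for weaker inhibition), and compound 1 stands in the middle of them. Compound 2 reads lower than compound 1 and compound 3 reads higher, with both gaps beyond the scatter. No two of these compounds differ in one place only, so no measured step offers a direct guide to the next change.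

That change leads to compound 4 (`COc1cc(NC(C)CCCNC(=O)Nc2ccc(Cl)c(C(F)(F)F)c2)c2ncccc2c1`), which keeps the core of compound 1 (4-chloro-3-(trifluoromethyl)phenyl in place of amino on an amide-type nitrogen), with 4-chloro-3-(trifluoromethyl)phenyl in place of amino on an amide-type nitrogen. In this assay a step towards a lower number is expected, of a size modestly beyond the scatter, though a result within the scatter would not be surprising. For the measured compounds named here, the expectation rests on the one lower value in hand, as compound 2 reads 5000 nM while compound 1 reads 16000 nM and this is weak support, since the data contain no direct precedent for the new group. The expected change is a 4.0-fold lower number from compound 1 to compound 4 (0.60 log units; beyond the scatter) (an estimate only). For compound 4 the estimated value is 4000 nM (expected range 800 nM to 20000 nM).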

Compound 4, half-maximal inhibitory concentration: 4000 nM
The estimate for compound 4 equals the measured number at the digits printed, within the range that was stated.
By their numbers in this assay, from the lowest: compounds 4 and 2 (each within the scatter of the next); then compound 1; then compound 3.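

In this assay, the amino end on the amide-type nitrogen now has a direct test, as 4-chloro-3-(trifluoromethyl)phenyl in place of amino gives a 4.0-fold lower number from compound 1 to compound 4 (0.60 log units; beyond the scatter). For the compounds shown here, this is the first pair here that differs in one place only, and it shows that this position can take a group of 11 heavy atoms with an aromatic ring in place of a single nitrogen, and that the number still falls, even though the entering group counts 0 hydrogen-bond donors and 0 hydrogen-bond acceptors where amino counted 1 of each. Nothing measured here accounts for this step, so it stands as an observation on one pair in one assay.

The compounds shown leave open which part of the new group carries the step, since a plain phenyl ring, or a ring bearing only the chloro or only the trifluoromethyl substituent, would separate those contributions. They also leave open how a non-aromatic group such as cyclohexyl, or an aryl group bearing a carboxylic acid, would read at this same position on the core of compound 1.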